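The source may report more compounds than this note shows. Statements on the series, on what has been measured and on what is new or still open speak of the compounds shown alone.

Measured in an ADME assay on L6 cells (Rattus norvegicus) for cytotoxicity; a lower number here means a stronger inhibitor, a higher number a weaker inhibitor:
- compound 1 `O=C(NN1Cc2ccccc2C1)c1ccccc1F`: 241000 nM
- compound 2 `CN(C)NC(=O)c1cc([N+](=O)[O-])ccc1Cl`: > 410000 nM

The reading for compound 2 is a limit of the assay, not a number: compound 2 stands at > 410000 nM. Compound 3 `O=C(NN1CCCCC1)c1cc([N+](=O)[O-])ccc1Cl` carries piperidin-1-yl in place of dimethylamino on an amide-type nitrogen. Among the compounds with values here, no step between measured compounds is available. Within the data shown here, the only numeric reading comes from compound 1 at 241000 nM, and the expectation leans on it. A modest move towards a lower number in this assay is expected, an estimated at least 1.6-fold lower number from compound 2 to compound 3 (0.21 log units; that floor lies within the scatter). For compound 3 the estimate is 250000 nM, with an expected range from 90000 nM to 500000 nM.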

Compound 3, half-maximal inhibitory concentration: > 352000 nM
Compound 3 was reported as a limit (the forecaster's own chance of this, stated with the estimate: 35%); middle value at least 1.4-fold (0.14 log units) from the limit.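

In this assay compound 2 and compound 3 are both reported only as limits, and no step can be read between them. Going by these compounds, whether piperidin-1-yl in place of dimethylamino on an amide-type nitrogen changes the number at all remains open.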